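The source may report more compounds than this note shows. Statements on the series, on what has been measured and on what is new or still open speak of the compounds shown alone.

Of the compounds shown here, two have been measured so far. Compound 1 `CCCCCCCCS(=O)(=O)Nc1cc(-c2ccc(OC)cc2)ccc1C(=O)O` gives 13300 nM in an assay on mitochondria (strain BALB/c) for inhibition of glycerol-3-phosphate acyltransferase 1, mitochondrial (Mus musculus), read by scintillation counting, with a stated time of 10 min; a higher number here means a weaker inhibitor, a lower number a stronger inhibitor. Compound 2 `CCCCCCCCS(=O)(=O)Nc1ccc(-c2cccc(Cl)c2)cc1C(=O)O` gives 8900 nM in this assay; the two numbers lie within the usual scatter of each other, so neither compound can be set above the other on these results. Compound 3 `CCCCCCCCS(=O)(=O)Nc1ccc(/C=C/c2ccccc2)cc1C(=O)O` has not yet been measured. It differs from compound 2 in one place: 2-phenylethenyl in place of 3-chlorophenyl on an aromatic carbon. Going by the values given here, no pair of measured compounds shows what such a change does in this assay, so nothing in the data points to a step in either direction beyond the scatter. Compound 3 is therefore expected to give a number close to that of compound 2. The step that this estimate means is a 1.0-fold higher number from compound 2 to compound 3 (0.00 log units; within the scatter), expected to stay within the scatter. The estimate for compound 3 in this assay is 9000 nM, in a range from 3000 nM to 30000 nM.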

Compound 3, half-maximal inhibitory concentration: 16300 nM
Compound 3: the middle estimate sits 1.8-fold (0.26 log units) below what was measured; measured number inside the range.
By their numbers in this assay, from the lowest: compounds 2, 1 and 3 (each within the scatter of the next).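

Putting 2-phenylethenyl in place of 3-chlorophenyl on this aromatic carbon, meta to a carboxy group and para to a large group, gives a 1.8-fold higher number from compound 2 to compound 3 (0.26 log units; within the scatter) in this assay. Going by these compounds alone, this is the first single exchange that can be read at this position, and it shows that the chlorine can leave and a double bond outside the aromatic rings can enter without the number moving beyond the scatter. Nothing measured offers an explanation for this result.

From the compounds shown here alone, it remains open whether an amine or a carboxylic acid on this carbon would move the number beyond the scatter. Since all the compounds shown lie within the scatter of their neighbours, it is also unknown what a shorter chain in place of the one they share would do.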